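The compounds below may be only part of what the source reports. "The series", "measured", "known", "first", "only" and "open" are said of these compounds alone.

Measured compounds and their values:

Compound 1 `CN(C(=O)NC(=O)c1ccc(F)c(F)c1)c1nc(C(F)(F)F)c(C(=O)N/N=C/c2ccc(C(F)(F)F)cc2)s1` – 6.07 ug/mL
Compound 2 `CN(C(=O)NC(=O)c1ccc([N+](=O)[O-])cc1)c1nc(C(F)(F)F)c(C(=O)N/N=C/c2ccc([N+](=O)[O-])cc2)s1` – 8.98 ug/mL
Compound 3 `CN(C(=O)NC(=O)c1ccc(Cl)c(Cl)c1)c1nc(C(F)(F)F)c(C(=O)N/N=C/c2ccc([N+](=O)[O-])cc2)s1` – 6.44 ug/mL

These three share one core and were each tested in a functional assay on A549 cells (Homo sapiens) for inhibition, read by MTT assay, with a stated time of 72 h; on this read-out higher numbers stand for weaker inhibition and lower numbers for stronger inhibition. Compound 3 gives the second highest of the three numbers; its nearest neighbour is compound 1, and its furthest is compound 2, yet both gaps fall within the usual scatter of repeated measurements, so the three compounds cannot be told apart on these numbers.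

Compound 4 `CN(C(=O)NC(=O)c1ccc(F)c(F)c1)c1nc(C(F)(F)F)c(C(=O)N/N=C/c2ccc([N+](=O)[O-])cc2)s1` has not yet been measured. It differs from compound 3 in one place: 3,4-difluorophenyl in place of 3,4-dichlorophenyl on a carbonyl carbon. Among the compounds with values here, the one measured step that touches the same position is the change from compound 2 to compound 3, where a 3,4-dichlorophenyl replaced a 4-nitrophenyl on that carbonyl carbon and gave a 1.4-fold lower number from compound 2 to compound 3 (0.14 log units; within the scatter). Compound 1, which carries the 3,4-difluorophenyl of compound 4 but a different group elsewhere, also gives a number in the same range as compound 3. Within the data shown here, no step seen so far has moved the read-out beyond the scatter.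

Compound 4 is therefore expected to give a 1.0-fold higher number from compound 3 to compound 4 (0.00 log units; within the scatter), meaning no step beyond the scatter. The estimated value for compound 4 is 6.5 ug/mL, within a range from 3.5 ug/mL to 12 ug/mL.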

Compound 4, half-maximal inhibitory concentration: 5.78 ug/mL
The estimate for compound 4 lay 1.1-fold (0.05 log units) above the measured number, within the range that was stated.
By their numbers in this assay, from the lowest: compounds 4, 1, 3 and 2 (each within the scatter of the next).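

In this assay, 3,4-difluorophenyl in place of 3,4-dichlorophenyl on the carbonyl carbon gives a 1.1-fold lower number from compound 3 to compound 4 (0.05 log units; within the scatter), so exchanging fluorine for chlorine on this ring also stays within the scatter. Replacing 4-nitrophenyl at that same place with 3,4-difluorophenyl gives a 1.6-fold lower number from compound 2 to compound 4 (0.19 log units; within the scatter), which means that the three groups now tested on this carbonyl carbon cannot be told apart in this read-out. Within the data shown here, a second place can also be read for the first time, since nitro in place of trifluoromethyl on an aromatic carbon gives a 1.1-fold lower number from compound 1 to compound 4 (0.02 log units; within the scatter), and this change cannot be separated from repeat-measurement scatter either.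

No supporting measurement is available to explain why these changes leave the numbers so close. Every group shown on this carbonyl carbon is a substituted phenyl ring, so it remains open whether an amine, a carboxylic acid or a longer alkyl chain in its place would move the number beyond the scatter.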